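This account rests on a few compounds, and the source may have more. Where it says the series, first, only, none or still open, it means among the compounds named here.

Measured compounds in an ADME assay on HCT-116 cells (Homo sapiens) for cytotoxicity, read by MTT assay; a lower number here means that less compound is tolerated, a higher number that more compound is tolerated:
- compound 1 `Cc1nc(-c2cccnc2)sc1-c1nnc(-c2ccccc2Cl)o1`: > 100 ug/mL
- compound 2 `COc1ccccc1-c1nnc(-c2sc(-c3cccnc3)nc2C)o1`: > 100 ug/mL
- compound 3 `Cc1nc(-c2cccnc2)sc1-c1nnc(-c2ccc(O)cc2)o1`: > 100 ug/mL

In this assay compound 3 gives > 100 ug/mL, which is a limit of the assay and not a number. Compound 1 and compound 2 likewise sit at a limit, as shown by the limit of > 100 ug/mL in this assay, at which 3 of the 3 values shown sit. Because of this the steps a step that the two limits leave unreadable from compound 1 to compound 3 and a step that the two limits leave unreadable from compound 2 to compound 3 cannot be sized. Compound 4 `Cc1nc(-c2cccnc2)sc1-c1nnc(-c2ccncc2)o1` differs from compound 3 by pyridin-4-yl in place of 4-hydroxyphenyl on an aromatic carbon. No measured step can therefore guide the expectation for this change; the only fact at hand is that every shown value sits at the limit. Compound 4 is expected to show no step beyond the scatter, a step that the limit leaves unreadable from compound 3 to compound 4, and most likely to report a limit again. The estimate for compound 4 is 120 ug/mL, with a range from 50 ug/mL to 300 ug/mL.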

Compound 4, half-maximal cytotoxic concentration: > 100 ug/mL
Compound 4 gave a limit, no number; the forecaster's own chance of this, stated with the estimate: 80%; the middle value lies beyond the limit too.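

Going by these compounds alone, compound 4, like compound 1, compound 2 and compound 3, gives a limit and not a number in this assay, so no step among them can be read: the limit of > 100 ug/mL in this assay, at which 4 of the 4 values shown sit. The compounds shown leave open at what concentration each becomes toxic to these cells, and whether they differ at all.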